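A few compounds are considered here, and "the series" means these few. Any claim that something is new, unique, unknown or untested is made for them only; others in the source may bear on it.

Measured compounds:
compound 1, `NS(=O)(=O)c1ccc(Nc2nc(N/N=C/c3ccc(C(F)(F)F)cc3)nc(Nc3ccccc3)n2)cc1`, 3100 nM in a functional assay on HCT-116 cells (Homo sapiens) for inhibition, read by sulforhodamine B assay, with a stated time of 48 h; on this read-out lower numbers stand for stronger inhibition of growth and higher numbers for weaker inhibition of growth;
compound 2, `Cc1nn(-c2ccccc2)cc1/C=N/Nc1nc(Nc2ccccc2)nc(Nc2ccc(S(N)(=O)=O)cc2)n1`, 2000 nM in this assay.

Among the compounds with values here, on these two numbers compound 2 sits within the scatter of compound 1, the only measured step being a 1.6-fold lower number from compound 1 to compound 2 (0.19 log units; within the scatter), a swap of one aryl group on the carbon with a double bond to nitrogen. Compound 3, `NS(=O)(=O)c1ccc(Nc2nc(N/N=C/c3ccccn3)nc(Nc3ccccc3)n2)cc1`, changes that same position again: pyridin-2-yl in place of 3-methyl-1-phenyl-1H-pyrazol-4-yl on a carbon with a double bond to nitrogen. Within the data shown here, the one step that bears on it, a 1.6-fold lower number from compound 1 to compound 2 (0.19 log units; within the scatter), is within the scatter, so an exchange of the group on this carbon has so far shifted the read-out in this assay by no more than chance. Among the measured compounds shown here, no measured step involves a pyridin-2-yl group, so the expectation rests on that single comparison. Compound 3 is therefore expected to give about 2500 nM in this assay, with a range from 1000 nM to 6500 nM. The expected step is a 1.3-fold higher number from compound 2 to compound 3 (0.10 log units; within the scatter), which is estimated to stay within the scatter.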

Compound 3, concentration for 50% growth inhibition: 390 nM
The estimate for compound 3 lay 6.4-fold (0.81 log units) above the measured number; measured number below the stated range.
By their numbers in this assay, from the lowest: compound 3; then compounds 2 and 1 (each within the scatter of the next).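

The group on the carbon with a double bond to nitrogen does affect the read-out in this assay: pyridin-2-yl gives a 5.1-fold lower number from compound 2 to compound 3 (0.71 log units; beyond the scatter) and a 7.9-fold lower number from compound 1 to compound 3 (0.90 log units; beyond the scatter), whereas the exchange shown earlier stayed within the scatter. Of the three groups, only pyridin-2-yl stands apart, and 3-methyl-1-phenyl-1H-pyrazol-4-yl and 4-(trifluoromethyl)phenyl remain within the scatter of each other. No measurement at hand accounts for this difference.

From the compounds shown here alone, it remains open whether pyridin-3-yl, pyridin-4-yl or an unsubstituted phenyl group on this carbon would match pyridin-2-yl, so the ring nitrogen cannot be separated from the exchange of the whole group. Also open, going by these compounds, is whether the step would hold if a carboxylic acid replaced the sulfonamide shared by all three compounds.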